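The source may hold more compounds than are shown below. What is called first, only, known or untested is meant among the compounds shown, and "the series" means these compounds.

Compound 1 `COc1ccc(-c2cc([C@@H](O)C[C@@H](O)CCc3ccc(Cl)cc3)no2)cc1` and compound 2 `O[C@@H](CCc1ccc(F)cc1)C[C@@H](O)c1cc(-c2ccccc2)on1` were both examined for cytotoxicity in an ADME assay on HepG2 cells (Homo sapiens) for cytotoxicity, read by MTT assay, with a stated time of 24 h; on this read-out higher numbers stand for weaker inhibition and lower numbers for stronger inhibition. For compound 1 the assay gives only a limit, > 100000 nM. For compound 2 the assay likewise gives only a limit, > 100000 nM. Both values thus sit at the limit of > 100000 nM in this assay, at which 2 of the 2 values shown sit, and compound 2 stands alongside compound 1 with no difference between them to be read. Compound 3 `COc1ccc(CC[C@H](O)C[C@@H](O)c2cc(-c3ccccc3)on2)cc1` carries one change relative to compound 2: methoxy in place of fluoro on an aromatic carbon. The step is expected to be none beyond the scatter, a number no higher from compound 2 to compound 3 (the limit leaves the size open). Compound 3 is accordingly estimated at about 100000 nM, within 50000 nM to 200000 nM, and most likely the assay will again report only a limit.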

Compound 3, half-maximal inhibitory concentration: > 100000 nM
Compound 3: a limit, no number (the forecaster's own chance of this, stated with the estimate: 85%); the middle value lies on the limit itself.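

Compound 3 also gives only a limit in this assay, so no step from compound 2 to compound 3 can be read: the limit of > 100000 nM in this assay, at which 3 of the 3 values shown sit.

The compounds shown leave open whether 4-fluorophenyl to 4-methoxyphenyl changes cytotoxicity at all, and what concentration, if any, would give half-maximal inhibition for any of the three.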